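A few compounds are considered here, and "the series" means these few. Any claim that something is new, unique, unknown or untested is made for them only; others in the source may bear on it.

Compound 1, `Fc1cccc(N2CCN(CCCCOc3ccc4c(c3)CCC4)CC2)c1`, is examined in a functional assay on the whole organism for inhibition, with Mus musculus as the target, at a dose of 25 mg/kg by the oral route (on this read-out lower numbers stand for less inhibition and higher numbers for more inhibition at the one dose given (going by the name of the read-out)), where compound 1 gives 17%. Among the three measured compounds this is the lowest number. Compound 3, `O=[N+]([O-])c1ccc(N2CCN(CCCOc3ccc4c(c3)CCC4)CC2)cc1`, lies nearest: in this assay compound 3 gives 26%, a number higher than that of compound 1 but within the usual scatter. Compound 2, `FC(F)(F)c1cccc(N2CCN(CCCOc3ccc4c(c3)CCC4)CC2)c1`, stands furthest away: in this assay compound 2 gives 73%, a number beyond the scatter from compound 1. Among the compounds with values here, no two of these measured compounds differ in only one place, so no single step between them can be read off.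

Compound 4, `O=[N+]([O-])c1ccc(N2CCN(CCCCOc3ccc4c(c3)CCC4)CC2)cc1`, is not yet measured. It differs from compound 1 in this way: 4-nitrophenyl in place of 3-fluorophenyl on an amine nitrogen in a ring. Compound 3 carries the same 4-nitrophenyl group on the amine nitrogen in a ring, though with a different chain, and compound 3 gives 26%. Compound 4 is therefore expected to sit near the numbers of compound 1 and compound 3 rather than near that of compound 2. In this assay compound 4 is estimated at 25%, with a range from 5% to 50%. For compound 4 the expected step is a number 8 percentage points higher from compound 1 to compound 4 (within the scatter), a small rise that may well remain within the scatter.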

Compound 4, a percentage reported as inhibition, in the whole organism at one dose (the size of the read-out at that dose, not a potency): 22%
Compound 4: the middle estimate sits 3 percentage points above what was measured; the measured number falls inside the stated range.
By their numbers in this assay, from the lowest: compounds 1, 4 and 3 (each within the scatter of the next); then compound 2.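

In this assay, within the data shown here, the exchange of 3-fluorophenyl for 4-nitrophenyl on an amine nitrogen in a ring gives a number 5 percentage points higher from compound 1 to compound 4 (within the scatter) and is the first change at a single place that can be read in this set. With the chain of compound 1 held fixed, the read-out at this one dose does not separate the two groups, although 4-nitrophenyl is the larger by heavy atoms and carries hydrogen-bond acceptors where 3-fluorophenyl has none. No measurement at hand speaks to why the two groups read alike.

Compound 2 gives 73% and differs from compound 1 in both the group on the ring nitrogen and the chain, so the compounds shown cannot tell which of these places goes with that number. Also open, going by these compounds, is what a plain phenyl or a 3-methoxyphenyl would give on the amine nitrogen in a ring, and what a longer chain would give with either of the two groups compared here.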